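Swapping the aryl group on the thiazole core

The compounds below may be only part of what the source reports. "The series", "measured", "known", "first", "only" and "open" are said of these compounds alone.

The series in an in vitro functional assay on HEK285-7 cells for antagonist activity at prostaglandin D2 receptor 2 (Homo sapiens), read by BRET and beta-arrestin recruitment (a lower number here means a stronger inhibitor, a higher number a weaker inhibitor), includes compound 1 `Cc1nc(-c2ccc(Cl)cc2)c(CC(=O)O)s1`, which gives 41000 nM, compound 2 `O=C(O)Cc1sc(C(Cc2ccccc2)c2ccccc2)nc1-c1ccc(Cl)cc1`, which gives 510 nM, and compound 3 `N#Cc1ccc(-c2nc(C(c3ccc(F)cc3)c3ccc(F)cc3)sc2CC(=O)O)cc1`, which gives 1500 nM. Among the three numbers compound 3 stands second highest: compound 2 lies nearest, with the lower number of the pair, and compound 1 lies furthest, with a much higher number, both gaps being beyond the usual scatter.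

Compound 4 `O=C(O)Cc1sc(C(c2ccc(F)cc2)c2ccc(F)cc2)nc1-c1ccco1` is not yet measured. It differs from compound 3 in one place: furan-2-yl in place of 4-cyanophenyl on an aromatic carbon. Among the compounds with values here, no pair of measured compounds here differs by the same change, so the size of this step has no direct precedent in the data.

On the structures alone the step is expected to be modest and towards a higher number, that is, a somewhat weaker inhibitor: the estimated change is a 2.0-fold higher number from compound 3 to compound 4 (0.30 log units; within the scatter). Compound 4 is therefore expected to give about 3000 nM in this assay, with a likely range from 800 nM to 12000 nM.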

Compound 4, half-maximal inhibitory concentration: 140 nM
Compound 4: middle estimate off by 21-fold (1.33 log units), on the high side, outside the stated range (below it).
By their numbers in this assay, from the lowest: compound 4; then compound 2; then compound 3; then compound 1.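

In this assay the aromatic carbon next to the ring nitrogen proves highly sensitive to the group it carries: furan-2-yl in place of 4-cyanophenyl gives an 11-fold lower number from compound 3 to compound 4 (1.03 log units; beyond the scatter) and so lies beyond the scatter. Within the data shown here, the earlier compounds included no pair differing in one place, so this is the first direct reading of a single change, and it shows that the six-membered aromatic ring with its nitrile is not required at this carbon for a lower number. Nothing measured here explains the size of this step.

As far as these compounds go, it remains open whether a plain phenyl or a thiophen-2-yl at this carbon would behave like compound 3 or like compound 4, and so whether the ring swap or the loss of the nitrile drives the step. Whether the same swap would act alike alongside the large group of compound 2 is also unresolved.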